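This account rests on a few compounds, and the source may have more. Where it says the series, first, only, none or still open, it means among the compounds named here.

Measured compounds:
compound 1, `C[C@@H]1CN(c2sc(C(F)(F)F)nc2-c2nc3cc(OCCO)ccc3[nH]2)CCN1C(=O)Cn1cnc2cccnc21`, 31 mL.min-1.g-1
compound 2, `Cc1nn(CC(=O)N2CCN(c3sc(C(F)(F)F)nc3-c3nc4ccccc4[nH]3)C[C@H]2C)cc1CN(C)C`, 29 mL.min-1.g-1

Both were run in an ADME assay on microsomes from liver (Mus musculus) for metabolic stability, read by LC-MS, using NADPH, with a stated time of 15 min, tested at 1 uM; on this read-out lower numbers stand for slow clearance and higher numbers for fast clearance. In this assay compound 1 gives 31 mL.min-1.g-1, and in this assay compound 2 gives 29 mL.min-1.g-1. The two numbers sit so close together that they fall within the usual scatter of this kind of measurement, so compound 2 cannot be told apart from compound 1 on these data.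

Compound 3 is `C[C@@H]1CN(c2sc(C(F)(F)F)nc2-c2nc3ccccc3[nH]2)CCN1C(=O)Cn1cnc2cccnc21`. It differs from compound 2 in one place: a group of 9 heavy atoms (6 carbon, 3 nitrogen; one five-membered aromatic ring with 2 hetero atoms, one six-membered aromatic ring with 1 hetero atom) in place of a group of 10 heavy atoms (7 carbon, 3 nitrogen; one five-membered aromatic ring with 2 hetero atoms), on a saturated chain carbon bound to a carbonyl carbon. The group that enters is the same one carried by compound 1 on the same chain carbon.

Among the measured compounds shown here, no step between measured compounds is available to lean on. Because compound 1 with this same group gives 31 mL.min-1.g-1, the number for compound 3 is expected to stay close to that of compound 2, with no step beyond the scatter. The estimated step of a 1.0-fold higher number from compound 2 to compound 3 (0.01 log units; within the scatter) is expected to be small. Compound 3 is estimated at 30 mL.min-1.g-1, within a range of 15 mL.min-1.g-1 to 60 mL.min-1.g-1.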

Compound 3, intrinsic clearance in microsomes in the Mus musculus assay: 104 mL.min-1.g-1
Beside the measured number, compound 3's estimate is 3.5-fold (0.54 log units) below it; the measured number lies above the stated range.
By their numbers in the Mus musculus assay, from the lowest: compounds 2 and 1 (each within the scatter of the next); then compound 3.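

The group on the saturated chain carbon bound to a carbonyl carbon clearly matters in the Mus musculus assay: the change from 4-((dimethylamino)methyl)-3-methyl-1H-pyrazol-1-yl to the group in compound 3 gives a 3.6-fold higher number from compound 2 to compound 3 (0.55 log units; beyond the scatter). The shared core matters too, since hydrogen in place of 2-hydroxyethoxy on an aromatic carbon gives a 3.4-fold higher number from compound 1 to compound 3 (0.53 log units; beyond the scatter). In a physicochemical assay for solubility, in simulated intestinal fluid (on this read-out higher numbers stand for higher solubility and lower numbers for lower solubility), compound 2 gives 645 ug/mL and compound 3 gives 214 ug/mL, so the change of group on the chain carbon also lowers solubility: the measured solubility of compound 2, 645 ug/mL, and of compound 3, 214 ug/mL, a 3.0-fold lower number (0.48 log units; beyond the scatter)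

From the compounds shown here alone, it remains open whether the dimethylaminomethyl part alone accounts for these steps, or whether a plain 3-methylpyrazol-1-yl or a morpholine on that chain carbon would do the same. Going by these compounds, the effect of 2-hydroxyethoxy and the 4-((dimethylamino)methyl)-3-methyl-1H-pyrazol-1-yl group together in one compound also stays unknown.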